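The source may hold more compounds than are shown below. What is called first, only, known or untested is meant among the compounds shown, and "the series" means these compounds.

Compound 1 `CC1(c2ccccc2)CC(=O)C(C2CC(c3ccc(-c4ccc(Br)cc4)cc3)Cc3ccccc32)=C(O)O1` gives 1310 nM in a functional assay on HCT-15 cells (Homo sapiens) for inhibition, with a stated time of 72 h; a higher number here means a weaker inhibitor, a lower number a stronger inhibitor. Compound 2 `COc1ccc(C2Cc3ccccc3C(C3=C(O)OC(C)(c4ccccc4)CC3=O)C2)cc1` gives only a limit of the assay, > 10000 nM. Compound 3 `CCC1(c2ccccc2)CC(=O)C(C2CC(c3ccc(-c4ccc(Br)cc4)cc3)Cc3ccccc32)=C(O)O1` likewise gives only a limit, > 10000 nM.

Compound 3 therefore stands at the edge of the measured range, a limit that two of the three values share (the limit of > 10000 nM in this assay, at which 2 of the 3 values shown sit). Compound 4 `CCC1(c2ccccc2)CC(=O)C(C2CC(c3ccc(OC)cc3)Cc3ccccc32)=C(O)O1` differs from compound 3 in one place: methoxy in place of 4-bromophenyl on an aromatic carbon. The same exchange has been measured once, on the scaffold of compound 1, where it gave an at least 7.6-fold higher number from compound 1 to compound 2 (0.88 log units; beyond the scatter). The other measured step is an at least 7.6-fold higher number from compound 1 to compound 3 (0.88 log units; beyond the scatter), the change that produced the limit value. Each of these two changes, taken singly, pushed the number beyond the limit, and compound 4 carries both of them. For the measured compounds named here, no measured step points toward a lower number. Since compound 3 already sits at the limit, the step that the limit leaves unreadable from compound 3 to compound 4 expected for compound 4 cannot be read as a firm number; compound 4 is expected to stay at or beyond the limit. Compound 4 is estimated at 40000 nM, with a range of 8000 nM to 300000 nM, and most likely it will be reported only as a limit.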

Compound 4, half-maximal inhibitory concentration: > 10000 nM
Compound 4 was reported as a limit; the forecaster's own chance of this, stated with the estimate: 90%; the middle value is on the limit's open side.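

Compound 4 is reported only as a limit, as are compound 2 and compound 3, so neither the step from compound 3 nor the step from compound 2 can be read. The compounds shown leave open how far beyond the limit of the assay compound 2, compound 3 and compound 4 lie.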